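A smaller side chain on the sulfonamide nitrogen

The source may hold more compounds than are shown below. What is called first, only, known or untested is meant among the compounds shown, and "the series" means these compounds.

In an ADME assay on Caco-2 cells (Homo sapiens) for permeability, in the apical to basolateral direction (a lower number here means that the compound crosses the layer more slowly, a higher number that the compound crosses the layer faster), compound 1 `Cn1cncc1CN1CC(N(CC2CCN(S(C)(=O)=O)CC2)S(=O)(=O)c2ccccn2)Cc2cc(C#N)ccc21` gives 0.1 10^-6 cm/s, and compound 2 `C=C(C)C(=O)N1CCC(CN(C2Cc3cc(C#N)ccc3N(Cc3cncn3C)C2)S(=O)(=O)c2ccccn2)CC1` gives 0.5 10^-6 cm/s, the higher of the two numbers, after a 5.0-fold higher number from compound 1 to compound 2 (0.70 log units; beyond the scatter). Compound 3 `Cn1cncc1CN1CC(N(CCn2cccc2)S(=O)(=O)c2ccccn2)Cc2cc(C#N)ccc21` differs from compound 2 by (1H-pyrrol-1-yl)methyl in place of 1-((1-methylethenyl)carbonyl)piperidin-4-yl on a saturated chain carbon bound to a sulfonamide nitrogen. For the measured compounds named here, no measured step covers this exchange; the only step seen concerns a group on the piperidine that leaves here, so it guides only weakly. A modest rise, a 2.0-fold higher number from compound 2 to compound 3 (0.30 log units; within the scatter), is expected, with much uncertainty. Compound 3 is therefore estimated at 1 10^-6 cm/s, within a range from 0.3 10^-6 cm/s to 3.5 10^-6 cm/s.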

Compound 3, apparent permeability: 12.4 10^-6 cm/s
The estimate for compound 3 lay 12-fold (1.09 log units) below the measured number, and the stated range ends below it.
By their numbers in this assay, from the lowest: compound 1; then compound 2; then compound 3.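

In this assay, the exchange on a saturated chain carbon bound to a sulfonamide nitrogen, with (1H-pyrrol-1-yl)methyl replacing the substituted piperidine, gives a 25-fold higher number from compound 2 to compound 3 (1.39 log units; beyond the scatter) and, measured against the other piperidine, a 120-fold higher number from compound 1 to compound 3 (2.09 log units; beyond the scatter) as well. Both steps are large, while the earlier change on the piperidine nitrogen was modest. Nothing shown here explains the rise.

As far as these compounds go, whether it comes from the pyrrole ring entering or the piperidine leaving stays open. A plain alkyl chain or a phenyl ring in this place would help separate the two.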